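A few compounds are considered here, and "the series" means these few. Any claim that something is new, unique, unknown or untested is made for them only; others in the source may bear on it.

Measured so far in a functional assay on SK-BR-3 cells (Homo sapiens) for antiproliferative activity, read by MTT assay, with a stated time of 72 h; on this read-out higher numbers stand for weaker inhibition and lower numbers for stronger inhibition:
compound 1 `CCc1ccccc1C(=O)Nc1ccc2nc(N3CCN(CC)CC3)cc(C)c2c1` gives 23900 nM
compound 2 `CCN1CCN(c2cc(C)c3cc(NC(=O)c4ccco4)ccc3n2)CC1` gives 37500 nM
compound 3 `CCN1CCN(c2cc(C)c3cc(NC(=O)c4cc5ccccc5[nH]4)ccc3n2)CC1` gives 2550 nM

Compound 3 holds the lowest number of the three in this assay. Its nearest neighbour is compound 1, with a 9.4-fold lower number from compound 1 to compound 3 (0.97 log units; beyond the scatter), and the furthest is compound 2, with a 15-fold lower number from compound 2 to compound 3 (1.17 log units; beyond the scatter). Both steps lie beyond the scatter, so compound 3 is the strongest inhibitor of the measured set.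

Compound 4 `CCN1CCN(c2cc(C)c3cc(NC(=O)c4ccc(Br)cc4)ccc3n2)CC1` is the next compound, differing from compound 3 at a single place: 4-bromophenyl in place of 1H-indol-2-yl on a carbonyl carbon.

Going by the values given here, two measured steps bear on this change. The step of a 9.4-fold lower number from compound 1 to compound 3 (0.97 log units; beyond the scatter) shows that a 1H-indol-2-yl on the carbonyl carbon gives a clearly lower number than a substituted phenyl at the same place, and the step of a 1.6-fold higher number from compound 1 to compound 2 (0.20 log units; within the scatter) shows that a furan-2-yl and a 2-ethylphenyl sit within the scatter of one another. A 4-bromophenyl resembles the substituted phenyl of compound 1 more than the 1H-indol-2-yl of compound 3, so the number is expected to move back upward, towards that of compound 1, by roughly a 5.9-fold higher number from compound 3 to compound 4 (0.77 log units; beyond the scatter).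

Compound 4 is therefore estimated at 15000 nM in this assay, with a range from 4000 nM to 50000 nM.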

Compound 4, half-maximal inhibitory concentration: 6310 nM
For compound 4 the middle estimate is 2.4-fold (0.38 log units) above the measured one, within the range that was stated.
By their numbers in this assay, from the lowest: compound 3; then compound 4; then compounds 1 and 2 (each within the scatter of the next).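

In this assay, going by these compounds alone, the change to 4-bromophenyl on the carbonyl carbon shows that the 1H-indol-2-yl is not the only group here that gives a low number: a single six-membered carbon ring, with no hydrogen-bond donor, comes within a modest step of the indole (a 2.5-fold higher number from compound 3 to compound 4 (0.39 log units; beyond the scatter)), although compound 3 keeps the lowest number, and it clearly improves on the furan-2-yl (a 5.9-fold lower number from compound 2 to compound 4 (0.77 log units; beyond the scatter)). Within the data shown here, the step from the 2-ethylphenyl (a 3.8-fold lower number from compound 1 to compound 4 (0.58 log units; beyond the scatter)) adds something the earlier compounds could not show, namely that two phenyl amides can differ beyond the scatter, so at this place the number depends on what the phenyl carries and not on the phenyl ring alone. No measurement available here explains why these groups differ.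

On these data alone, what stays open is whether the bromine itself accounts for the lower number, which a plain phenyl or a 4-chlorophenyl at the same carbonyl carbon would test. As far as these compounds go, it is also open whether a phenyl carrying an amine or a carboxylic acid would keep the number near that of compound 4.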